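Methyl in place of hydrogen on the shared core

This account rests on a few compounds, and the source may have more. Where it says the series, first, only, none or still open, it means among the compounds named here.

Compound 1 `COc1cc2c(cc1O)C(=O)/C(=C/c1cc(OC)c(OC)c(OC)c1)C2` and compound 2 `COc1cc2c(cc1O)C(=O)/C(=C/c1ccc(OC)c(OC)c1OC)C2` are built from the same atoms joined differently; the difference between the two cores is not broken down here. In a functional assay on A549 cells (Homo sapiens) for antiproliferative activity, read by MTT assay, with a stated time of 48 h (a lower number here means a stronger inhibitor of growth, a higher number a weaker inhibitor of growth), compound 1 gives only a limit, > 10000 nM. Among the compounds with values here, compound 2 gives 3420 nM in this assay, the only number among the three values so far. Compound 3 `COc1cc2c(cc1OC)C(=O)/C(=C/c1cc(OC)c(OC)c(OC)c1)C2` comes from compound 1 by methyl in place of hydrogen on an oxygen on an aromatic ring. In this assay compound 3 also gives a limit, > 10000 nM. The step that the two limits leave unreadable from compound 1 to compound 3 is therefore not readable, because of the limit of > 10000 nM in this assay, at which 2 of the 3 values shown sit. Compound 4 `COc1cc2c(cc1OC)C(=O)/C(=C/c1ccc(OC)c(OC)c1OC)C2` comes from compound 2 by the same kind of change, (methyl in place of hydrogen on an oxygen on an aromatic ring), at a place described in the same words. The change thus occurs twice in the series, yet its size has not been read anywhere. From compound 2 to compound 4 a step of a 1.8-fold higher number from compound 2 to compound 4 (0.24 log units; within the scatter) is expected, resting on compound 2 at 3420 nM and on the fact that neither compound 1 nor compound 3 gives a number. Compound 4 is estimated at 6000 nM, within 2000 nM to 20000 nM.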

Compound 4, concentration for 50% growth inhibition: > 10000 nM
Compound 4 gave a limit, no number (the forecaster's own chance of this, stated with the estimate: 35%); middle value at least 1.6-fold (0.22 log units) away from the limit.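

Going by these compounds, on the core of compound 2, methyl in place of hydrogen on an oxygen on an aromatic ring reads in this assay as an at least 2.9-fold higher number from compound 2 to compound 4 (0.46 log units; beyond the scatter), a step beyond the scatter whose full size stays unknown. Compound 4 gives > 10000 nM, which is a limit and not a number. The same change on the core of compound 1 cannot be read, and whether the step carries from one core to the other cannot be said, because both ends of that pair sit at the limit: the limit of > 10000 nM in this assay, at which 3 of the 4 values shown sit.

Only hydroxy and methoxy are shown at this oxygen, so it remains open how a longer chain there, or a chain ending in an amine or a carboxylic acid, would read. Within the data shown here, with compound 2 at 3420 nM as the only number, the comparison between the two cores also rests on a single measured value.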